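The compounds below may be only part of what the source reports. "The series", "measured", "known", "first", "only" and "open" are said of these compounds alone.

Working notes on the series. The shared core of compound 1 `Cc1ccc(OCC(=O)N(Cc2cccs2)c2nccs2)cc1` is varied only on the amide-type nitrogen. In an assay on HEK293 cells for agonist activity at transient receptor potential cation channel subfamily M member 8 (Homo sapiens), read by fluorescence and calcium flux, with a stated time of 15 min (a lower number here means that less compound is needed, a higher number that more compound is needed for the effect), compound 1 gives 2240 nM, compound 2 `Cc1ccc(OCC(=O)N(C)Cc2cccs2)cc1` gives 400 nM and compound 3 `Cc1ccc(OCC(=O)N(CCO)Cc2cccs2)cc1` gives 900 nM, the second highest of the three numbers: a 2.3-fold higher number from compound 2 to compound 3 (0.35 log units; beyond the scatter) and a 2.5-fold lower number from compound 1 to compound 3 (0.40 log units; beyond the scatter). Compound 4 `Cc1ccc(OCC(=O)N(O)Cc2cccs2)cc1` differs from compound 3 by hydroxy in place of 2-hydroxyethyl on an amide-type nitrogen. Among the compounds with values here, the steps that bear on this are a 5.6-fold lower number from compound 1 to compound 2 (0.75 log units; beyond the scatter) and a 2.3-fold higher number from compound 2 to compound 3 (0.35 log units; beyond the scatter): the smaller substituent on this nitrogen gave the lower number, and the hydroxyl-bearing chain cost a modest amount. A small hydroxyl substituent is therefore expected to give a modest lower number, possibly within the scatter. Compound 4 is estimated at 650 nM, range 250 nM to 2000 nM. The expected step is a 1.4-fold lower number from compound 3 to compound 4 (0.14 log units; within the scatter).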

Compound 4, half-maximal effective concentration: 8000 nM
Beside the measured number, compound 4's estimate is 12-fold (1.09 log units) below it; measured number above the stated range.
By their numbers in this assay, from the lowest: compound 2; then compound 3; then compound 1; then compound 4.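

The rule that a smaller group on the amide-type nitrogen gives a lower number, suggested by compound 1 and compound 2, does not hold for compound 4: hydroxy gives an 8.9-fold higher number from compound 3 to compound 4 (0.95 log units; beyond the scatter) and a 20-fold higher number from compound 2 to compound 4 (1.30 log units; beyond the scatter). Even the 1,3-thiazol-2-yl group compares favourably, with a 3.6-fold higher number from compound 1 to compound 4 (0.55 log units; beyond the scatter), so an oxygen bound directly to this nitrogen is not interchangeable with the 2-hydroxyethyl chain, despite equal donor and acceptor counts. No available evidence accounts for this result.

Still open, going by these compounds, is whether methoxy or an amine on this nitrogen behaves like hydroxy, and whether a longer chain such as 3-hydroxypropyl behaves like 2-hydroxyethyl.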